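Removing a Chloro Group: Expected Effect on Lipophilicity

This account rests on a few compounds, and the source may have more. Where it says the series, first, only, none or still open, it means among the compounds named here.

Compound 1 `CCC/N=C1\S/C(=C\c2ccc(O)c(Cl)c2)C(=O)N1c1ccccc1C`: 3.8
Compound 2 `CCC/N=C1\S/C(=C\c2ccc(O)c(Cl)c2)C(=O)N1C1CC1`: 3.4
Compound 3 `COCC/N=C1\S/C(=C\c2ccc(O)c(Cl)c2)C(=O)N1c1ccccc1C`: 2.9

The three measured compounds share one core and each differs from compound 1 at a single point. In a physicochemical assay for lipophilicity, read by HPLC, at pH 7.4 (a higher number here means a more lipophilic compound, a lower number a more polar compound), compound 1 stands highest of the three numbers. Compound 2 sits lower by a number 0.40 log units lower from compound 1 to compound 2 (beyond the scatter), with cyclopropyl in place of 2-methylphenyl on an amide-type nitrogen in a ring. Compound 3 sits lower still by a number 0.90 log units lower from compound 1 to compound 3 (beyond the scatter), with methoxy in place of methyl on a saturated chain carbon, two bonds along the chain from a double-bonded nitrogen.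

Compound 4 `CCC/N=C1\S/C(=C\c2ccc(O)cc2)C(=O)N1c1ccccc1C` has not yet been measured. It differs from compound 1 by hydrogen in place of chloro on an aromatic carbon. Neither measured step touches this part of the molecule; both alter groups hanging from the core rather than the aromatic ring carrying the hydroxy group, so they give no direct guide to the size of this step. They do show that single changes at one point moved the number by modest amounts beyond the scatter. Compound 4 is expected to give about 3.2, within 2.8 to 3.6. The expected step from compound 1 to compound 4 is a number 0.60 log units lower from compound 1 to compound 4 (beyond the scatter), a modest move downward beyond the scatter.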

Compound 4, distribution coefficient: 3.5
Beside the measured number, compound 4's estimate is 0.30 log units below it, and the stated range covers the measured number.
By their numbers in this assay, from the lowest: compound 3; then compounds 2, 4 and 1 (each within the scatter of the next, the first and the last beyond it).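

In this assay, the change from 3-chloro-4-hydroxyphenyl to 4-hydroxyphenyl gives a number 0.30 log units lower from compound 1 to compound 4 (within the scatter), so this assay does not tell these two compounds apart. This is the first reading at an aromatic carbon ortho to a hydroxy group, and among the three single changes shown, it is the only one that stays within the scatter, whereas a number 0.40 log units lower from compound 1 to compound 2 (beyond the scatter) and a number 0.90 log units lower from compound 1 to compound 3 (beyond the scatter) are both printed as beyond it. No measurement shown here gives a reason for the size of this step.

As far as these compounds go, only chloro and hydrogen have been seen on this carbon, so it remains open whether a larger or very different group there, such as an amine or a carboxylic acid, would also stay within the scatter of compound 1. From the compounds shown here alone, it is also open whether hydrogen in place of chloro would give a similar reading with cyclopropyl on the ring nitrogen, as in compound 2, or with the methoxy-bearing chain of compound 3.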